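The compounds below may be only part of what the source reports. "The series", "measured", "known", "first", "only" and "open" are said of these compounds alone.

Measured in a functional assay on K562 cells (Homo sapiens) for cytotoxicity, read by MTT assay, with a stated time of 48 h; on this read-out lower numbers stand for stronger inhibition and higher numbers for weaker inhibition:
- compound 1 `COc1cc(-c2noc(N)c2-c2ccc(Cl)cc2)cc(OC)c1OC`: 640 nM
- compound 2 `COc1ccc(-c2c(-c3cc(OC)c(OC)c(OC)c3)noc2NC(C)=O)cc1`: 380 nM
- compound 3 `COc1ccc(-c2c(-c3cc(OC)c(OC)c(OC)c3)noc2NC(C)=O)cc1OC`: 3710 nM

Compound 3 gives the highest number of the three, beyond the scatter from both of the others. Compound 4 `COc1cc(-c2noc(NC(C)=O)c2-c2ccc(Cl)cc2)cc(OC)c1OC` has not yet been measured. It differs from compound 3 as follows: 4-chlorophenyl in place of 3,4-dimethoxyphenyl on an aromatic carbon. For the measured compounds named here, the one measured step that touches this aromatic substituent is a 9.8-fold higher number from compound 2 to compound 3 (0.99 log units; beyond the scatter), with methoxy in place of hydrogen on an aromatic carbon. Compound 4 does not carry that added methoxy, which points toward a lower number. Compound 1, which has the 4-chlorophenyl but no acetamido group, reads 640 nM, so the same substituent is seen with a number well under that of compound 3. Going by the values given here, no measured pair isolates the swap of methoxy-bearing phenyl for 4-chlorophenyl with the acetamido group in place. A modest change is therefore expected, estimated as a 6.2-fold lower number from compound 3 to compound 4 (0.79 log units; beyond the scatter). For compound 4 the expected value is 600 nM, with an estimated range of 150 nM to 2400 nM.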

Compound 4, half-maximal inhibitory concentration: 3620 nM
Beside the measured number, compound 4's estimate is 6.0-fold (0.78 log units) below it, and the stated range ends below it.
By their numbers in this assay, from the lowest: compounds 2 and 1 (each within the scatter of the next); then compounds 4 and 3 (each within the scatter of the next).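

In this assay, the aromatic group next to the ring atom that bears an acetamido group can change from 3,4-dimethoxyphenyl to 4-chlorophenyl with no difference beyond the scatter (a 1.0-fold lower number from compound 3 to compound 4 (0.01 log units; within the scatter)), so the high number of compound 3 does not depend on its added methoxy alone. Chloro in place of the methoxy of compound 2 gives a 9.5-fold higher number from compound 2 to compound 4 (0.98 log units; beyond the scatter), which leaves compound 2 as the only acetamido compound here with a low number. With the 4-chlorophenyl held fixed, the acetyl on the nitrogen also matters: a 5.7-fold higher number from compound 1 to compound 4 (0.75 log units; beyond the scatter).

Going by these compounds, whether acetyl has a similar effect alongside the 4-methoxyphenyl remains open, as do an unsubstituted phenyl at this carbon and a propionyl group on the nitrogen. No available evidence accounts for these steps.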